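Swapping an ester tail for a bromophenyl ring

This account rests on a few compounds, and the source may have more. Where it says the series, first, only, none or still open, it means among the compounds named here.

Compound 1 `O=C(O)Cn1c(SCCCCOc2ccccc2)nc2ccccc21`: 1400 nM
Compound 2 `O=C(O)Cn1c(SCCCc2ccccc2)nc2ccccc21`: 475 nM
Compound 3 `CCOC(=O)CCCSc1nc2ccccc2n1CC(=O)O`: 4410 nM

In an assay on HEK293 cells for displacement of a labelled ligand from prostaglandin D2 receptor 2 (Homo sapiens) (on this read-out higher numbers stand for weaker inhibition and lower numbers for stronger inhibition), compound 3 gives the highest number of the three, so it is the weakest inhibitor here. Compound 4 `O=C(O)Cn1c(SCc2ccc(Br)cc2)nc2ccccc21` is not yet measured; it differs from compound 3 by 4-bromophenyl in place of 2-(ethoxycarbonyl)ethyl on a saturated chain carbon bound to a sulfur. Going by the values given here, the steps that bear on this are a 9.3-fold higher number from compound 2 to compound 3 (0.97 log units; beyond the scatter) and a 3.2-fold higher number from compound 1 to compound 3 (0.50 log units; beyond the scatter), both showing that the ethoxycarbonyl tail gave higher numbers than an aromatic or phenoxy tail. Reversing that, with an aromatic ring entering on a shorter tether, a lower number is expected for compound 4, though the tether length has no measured precedent. Compound 4 is estimated at 800 nM, between 250 nM and 2500 nM, which would mean an expected step of a 5.5-fold lower number from compound 3 to compound 4 (0.74 log units; beyond the scatter) in this assay.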

Compound 4, half-maximal inhibitory concentration: 220 nM
For compound 4 the middle estimate is 3.6-fold (0.56 log units) above the measured one; measured number below the stated range.
By their numbers in this assay, from the lowest: compound 4; then compound 2; then compound 1; then compound 3.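

In this assay, going by these compounds alone, the swap of 2-(ethoxycarbonyl)ethyl for 4-bromophenyl on a saturated chain carbon bound to a sulfur gives the largest step so far (a 20-fold lower number from compound 3 to compound 4 (1.30 log units; beyond the scatter)). The earlier steps shown here changed only a group three bonds along the chain from a sulfur, whereas this one shows that an aromatic ring on the carbon bound to the sulfur also goes with a low number. Nothing measured here explains the step.

Going by these compounds, the bromine and the shorter tether arrive together, so the share of each remains open. A longer chain carrying the same 4-bromophenyl, or an amine in place of the bromine, would help separate them.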